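The compounds below may be only part of what the source reports. "The series", "measured", "known", "first", "only" and "open" are said of these compounds alone.

Working notes on the diacylhydrazine series.

Three compounds have numbers in an assay on cells for agonist activity at ecdysone receptor (Bombyx mori), read by a luciferase reporter, with a stated time of 24 h; a higher number here means that more compound is needed for the effect, a lower number that less compound is needed. Compound 1 `CC(C)(C)N(NC(=O)c1ccccc1)C(=O)c1ccccc1C(F)(F)F` gives 631 nM. Compound 2 `COc1cccc(C(=O)NN(C(=O)c2ccccc2Cl)C(C)(C)C)c1` gives 52.5 nM. Compound 3 `COc1cccc(C(=O)NN(C(=O)c2cc(C)cc(C)c2)C(C)(C)C)c1` gives 66.1 nM. Compound 3 stands second highest of the three: its nearest neighbour is compound 2, and its furthest is compound 1, whose number is beyond the scatter from it. Within the data shown here, the one step measured in a single place is a 1.3-fold higher number from compound 2 to compound 3 (0.10 log units; within the scatter), which lies within the scatter.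

Compound 4 `CCCCCCCC(=O)NN(C(=O)c1cc(C)cc(C)c1)C(C)(C)C` is not yet measured. The change from compound 3 is heptyl in place of 3-methoxyphenyl on a carbonyl carbon. Among the measured compounds shown here, no measured step touches this carbonyl carbon: the step from compound 2 to compound 3 changes the other carbonyl substituent, and compound 1 differs from the rest in more than one place. For the measured compounds named here, the change removes the aromatic ring and its hydrogen-bond acceptor on this side, and nothing among the measured compounds shows how this assay responds to that. The expectation for compound 4 is therefore a weaker number than compound 3, worded with wide uncertainty, as a step of a 23-fold higher number from compound 3 to compound 4 (1.36 log units; beyond the scatter). Compound 4 is expected to give about 1500 nM, with a range from 200 nM to 10000 nM.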

Compound 4, half-maximal effective concentration: 97.7 nM
Estimate against measurement, compound 4: 15-fold (1.19 log units) above, and the stated range ends above it.
By their numbers in this assay, from the lowest: compounds 2, 3 and 4 (each within the scatter of the next); then compound 1.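

Among these compounds, this is the first measured step at this carbonyl carbon: in this assay, heptyl in place of 3-methoxyphenyl gives a 1.5-fold higher number from compound 3 to compound 4 (0.17 log units; within the scatter), so the assay does not tell these two groups apart here. With 3,5-dimethylphenyl on the other carbonyl, neither the six-membered aromatic ring nor the hydrogen-bond acceptor that leaves with 3-methoxyphenyl is needed for a number within the scatter of compound 3, and a chain with no ring serves at this position as well as the aryl group does. No measurement at hand explains why the two groups give numbers this close.

The compounds shown leave open how far this holds along a series of chains, since one chain and one aryl group say nothing about a shorter chain, a longer chain, or a chain ending in an amine or a carboxylic acid at this carbonyl carbon. They also leave open whether heptyl gives the same result with 2-chlorophenyl on the other carbonyl, as in compound 2, where the two carbonyl substituents might not act independently.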